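Aryl swap on the fused core: compound 3 to compound 4

The source may report more compounds than this note shows. Statements on the series, on what has been measured and on what is new or still open speak of the compounds shown alone.

Compound 1 `COc1ccc(-c2cc3nccc(-c4cc(OC)c(OC)c(OC)c4)n3n2)cc1N` gives 251 nM in a functional assay on HCT-116 cells (Homo sapiens) for inhibition, read by CCK-8 assay, with a stated time of 48 h; a lower number here means a stronger inhibitor, a higher number a weaker inhibitor. Compound 2 `COc1cc(-c2ccnc3cc(-c4ccccc4)nn23)cc(OC)c1OC` gives 3880 nM in this assay, and compound 3 `COc1cc(-c2ccnc3cc(-c4ccc(F)cc4)nn23)cc(OC)c1OC` gives 5030 nM in this assay. Compound 3 carries the highest number of the three; its nearest neighbour is compound 2, a gap within the scatter, and the furthest is compound 1, a gap beyond the scatter. The steps of a 15-fold higher number from compound 1 to compound 2 (1.19 log units; beyond the scatter) and a 20-fold higher number from compound 1 to compound 3 (1.30 log units; beyond the scatter) are both large, whereas a 1.3-fold higher number from compound 2 to compound 3 (0.11 log units; within the scatter) stays within the scatter.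

Compound 4 `COc1cc(-c2ccnc3cc(-c4ccc(C)c(C)c4)nn23)cc(OC)c1OC` differs from compound 3 as follows: 3,4-dimethylphenyl in place of 4-fluorophenyl on an aromatic carbon. The measured step that bears on this is a 1.3-fold higher number from compound 2 to compound 3 (0.11 log units; within the scatter), itself a swap of a substituent on the same phenyl, and it stayed within the scatter. The two large steps concern loss of the 3-amino-4-methoxyphenyl, which is already absent from compound 3 and from compound 4. The expected step is therefore a 1.1-fold lower number from compound 3 to compound 4 (0.05 log units; within the scatter), none beyond the scatter in either direction. Compound 4 is estimated at 4500 nM, with a range from 1500 nM to 13000 nM.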

Compound 4, half-maximal inhibitory concentration: 261 nM
For compound 4 the middle estimate is 17-fold (1.24 log units) above the measured one, and the stated range ends above it.
By their numbers in this assay, from the lowest: compounds 1 and 4 (each within the scatter of the next); then compounds 2 and 3 (each within the scatter of the next).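

At this place on the five-membered aromatic ring, the change in the aryl group can matter even when the 3-amino-4-methoxyphenyl is absent: in this assay, 3,4-dimethylphenyl gives a 19-fold lower number from compound 3 to compound 4 (1.28 log units; beyond the scatter) and a 15-fold lower number from compound 2 to compound 4 (1.17 log units; beyond the scatter), while the fluoro-for-hydrogen swap gave only a 1.3-fold higher number from compound 2 to compound 3 (0.11 log units; within the scatter). The amino and methoxy groups are therefore not needed for a value at the level of compound 1, as a 1.0-fold higher number from compound 1 to compound 4 (0.02 log units; within the scatter) shows, though compound 3 goes against any reading that substitution on this phenyl alone is enough. Nothing measured here explains the gain at this position.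

Open, on these data alone, is whether both methyl groups are needed, which 3-methylphenyl and 4-methylphenyl would test. Also open, as far as these compounds go, is how a longer chain, such as 3,4-diethylphenyl, or a carboxylic acid on this phenyl would read.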